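Swapping the amide headgroup on a slowly cleared scaffold

The source may report more compounds than this note shows. Statements on the series, on what has been measured and on what is new or still open speak of the compounds shown alone.

Compound 3 `O=C(N[C@H]1CN(S(=O)(=O)c2ccccc2)C[C@@H]1C(=O)N[C@H]1CCCNC1)c1cc(C2CC2)n[nH]1` is one of three compounds for which a rat liver cell measurement has been made. In an ADME assay on cells (Hepatocyte, Rattus norvegicus) for metabolic stability (a lower number here means slower removal, a higher number faster removal of the compound), compound 3 gives < 1 uL/min, which is a limit of the assay rather than a number. Compound 2 `Cc1csc(C(=O)N[C@H]2CN(S(=O)(=O)c3ccccc3)C[C@@H]2C(=O)N[C@H]2CCCNC2)n1` shares the core and differs only in the headgroup on the carbonyl carbon. In this assay compound 2 gives < 1 uL/min, again a limit. The step that the two limits leave unreadable from compound 2 to compound 3 therefore cannot be sized. Compound 1 `Cc1ccc2[nH]c(C(=O)N[C@H]3CN(S(=O)(=O)c4ccccc4)C[C@@H]3C(=O)NC[C@H]3CCCN3C)cc2c1` differs at the other amide as well; in this assay compound 1 gives 21 uL/min. Among the compounds with values here, no step is defined between compound 1 and the others because the limit of < 1 uL/min in this assay, at which 2 of the 3 values shown sit, leaves the lower end of the comparison open.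

Compound 4 `O=C(N[C@H]1CN(S(=O)(=O)c2ccccc2)C[C@@H]1C(=O)N[C@H]1CCCNC1)c1nnc(-c2ccc(F)cc2)s1` carries a new headgroup: a group of 12 heavy atoms (8 carbon, 2 nitrogen, 1 fluorine, 1 sulfur; one five-membered aromatic ring with 3 hetero atoms, one six-membered aromatic ring of carbon only) in place of a group of 8 heavy atoms (6 carbon, 2 nitrogen; one three-membered non-aromatic ring of carbon only, one five-membered aromatic ring with 2 hetero atoms), on a carbonyl carbon. Within the data shown here, no measured step bears readably on this change. The step of an at least 3.0-fold higher number from compound 3 to compound 4 (0.47 log units; beyond the scatter) is expected to stay small, though it may leave the limit. Compound 4 is estimated at 3 uL/min, with a range from 1 uL/min to 15 uL/min.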

Compound 4, intrinsic clearance in a liver preparation (reported as CLH), per the amount of preparation that the assay uses: 1.2 uL/min
Compound 4: middle estimate off by 2.5-fold (0.40 log units), on the high side, within the range that was stated.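

In this assay, within the data shown here, compound 4 gives 1.2 uL/min, the first number at this position that is not a limit among compounds sharing this core. The headgroup on the carbonyl carbon can thus grow to 12 heavy atoms, with a second aromatic ring and a fluorine, and removal stays slow in these cells, as the steps of an at least 1.2-fold higher number from compound 3 to compound 4 (0.07 log units; that floor lies within the scatter) and an at least 1.2-fold higher number from compound 2 to compound 4 (0.07 log units; that floor lies within the scatter) show. Both steps are floors rather than sizes, and neither lies beyond the scatter: the limit of < 1 uL/min in this assay, at which 2 of the 4 values shown sit.

On these data alone, whether the fluorine or the six-membered aromatic ring contributes anything to the value of compound 4 stays open. So does how a headgroup carrying an amine or a carboxylic acid would read at this carbonyl carbon on the same core.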